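A few compounds are considered here, and "the series" means these few. Any claim that something is new, unique, unknown or untested is made for them only; others in the source may bear on it.

Measured compounds:
- compound 1 `CN(C)CCC1CCCC(c2ccccc2)C1`: 4.2 nM
- compound 2 `c1ccc([C@H]2CCC[C@@H](CCN3CCN(c4ccccc4)CC3)C2)cc1`: 16 nM
- compound 3 `CN(C)CC[C@@H]1CCC[C@H](c2ccccc2)C1`: 14 nM

In an assay on membranes from brain for displacement of a labelled ligand from Sigma non-opioid intracellular receptor 1 (Cavia porcellus), read by scintillation counting, with a stated time of 120 min (on this read-out higher numbers stand for weaker inhibition and lower numbers for stronger inhibition), compound 2 gives the highest of the three numbers. Against compound 3 the gap is within the scatter, so the two cannot be ordered; against compound 1 compound 2 stands clearly higher.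

Compound 4 `c1ccc([C@H]2CCC[C@H](CCN3CCN(c4ccccc4)CC3)C2)cc1` keeps every atom and bond of compound 2; (the two compounds have the same atoms and bonds and differ only in configuration as drawn: 1 of 2 stereo elements differ; a stereocentre at a saturated ring carbon is drawn R in compound 2 and S in compound 4). So compound 4 is the other diastereomer of compound 2.

Among the compounds with values here, only one measured step speaks to such a change: a 3.3-fold higher number from compound 1 to compound 3 (0.52 log units; beyond the scatter). There compound 1, drawn without configuration, gave the lower number, and compound 3, one defined diastereomer, the higher, a difference that rests on (the fact that one of compounds 1 and 3 is drawn with a defined configuration and the other without, at the place where they differ). If compound 1 is a mixture, its other diastereomer would have to bind more strongly than compound 3. By that analogy compound 4 is expected to give a lower number than compound 2, a step of about a 2.7-fold lower number from compound 2 to compound 4 (0.43 log units; beyond the scatter), modest and uncertain.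

For compound 4 the estimate in this assay is 6 nM, with a range from 2 nM to 25 nM.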

Compound 4, inhibition constant: 13 nM
Compound 4: the middle estimate sits 2.2-fold (0.34 log units) below what was measured; the range from low to high includes it.
By their numbers in this assay, from the lowest: compound 1; then compounds 4, 3 and 2 (each within the scatter of the next).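

In this assay, redrawing one stereocentre at a saturated ring carbon gives a 1.2-fold lower number from compound 2 to compound 4 (0.09 log units; within the scatter), so compound 2 and compound 4 cannot be ordered. With the larger amine end these compounds carry, this assay therefore does not separate the two configurations at this carbon. Unlike the earlier step, which set a compound of undefined configuration against a defined one, this comparison has a defined configuration on both sides, so it can be read directly as a change at a single stereocentre: the fact that compounds 2 and 4 differ only in the configuration as drawn

Still open, from the compounds shown here alone, is whether this carbon would matter as little with a morpholine as the amine or with a longer chain. Also open is what lies behind the number of compound 1, 4.2 nM, since its configuration is not drawn and none of the defined compounds shown stands clearly apart from the others.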